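This account rests on a few compounds, and the source may have more. Where it says the series, first, only, none or still open, it means among the compounds named here.

Measured compounds:
Compound 1, `CNS(=O)(=O)c1ccc(-c2cnc(N)c(-c3ccc(OC)nc3)c2)cc1`, in a physicochemical assay for solubility, read by nephelometry, measured as kinetic solubility, at pH 2 (on this read-out lower numbers stand for lower solubility and higher numbers for higher solubility), gives > 100 ug/mL, which is a limit of the assay.
Compound 2, `COc1ccc(-c2cc(-c3ccc(NS(C)(=O)=O)cc3)cnc2N)cn1`, in this assay gives > 100 ug/mL, also a limit of the assay.
Compound 3, `COc1ccc(-c2cc(-c3ccc(-n4cccn4)cc3)cnc2N)cn1`, in this assay gives > 100 ug/mL, again a limit of the assay.

Compound 3 thus stands at the same limit as the other two measured compounds: the limit of > 100 ug/mL in this assay, at which 3 of the 3 values shown sit. The steps between the measured compounds, a step that the two limits leave unreadable from compound 1 to compound 2, a step that the two limits leave unreadable from compound 1 to compound 3 and a step that the two limits leave unreadable from compound 2 to compound 3, cannot be sized, since both ends of each lie at that limit.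

Compound 4, `COc1ccc(-c2cc(-c3ccc(C(=O)N(C)C)cc3)cnc2N)cn1`, differs from compound 3 in one place: dimethylcarbamoyl in place of 1H-pyrazol-1-yl on an aromatic carbon. The measured steps bear on this change only in that every measured compound sits at the limit; none of them gives a readable size or direction. The step from compound 3 to compound 4 in this assay is therefore expected to be a number no higher from compound 3 to compound 4 (the limit leaves the size open), that is, no step beyond the scatter, with the read-out most likely again a limit. For compound 4 the estimated value in this assay is 100 ug/mL, with a range from 50 ug/mL to 200 ug/mL.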

Compound 4, solubility: > 100 ug/mL
Compound 4: no number, only a limit; the forecaster's own chance of this, stated with the estimate: 80%; the middle value sits exactly at the limit.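

In this assay compound 4 gives > 100 ug/mL, a limit of the assay. No step from compound 1, compound 2 or compound 3 to compound 4 can be read, because all the compounds share one limit: the limit of > 100 ug/mL in this assay, at which 4 of the 4 values shown sit.

As far as these compounds go, whether these four compounds differ at all in this assay, and by how much, stays open.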